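Amino in place of dimethylamino in the hydroxyalkyl series

The compounds below may be only part of what the source reports. "The series", "measured", "known", "first", "only" and "open" are said of these compounds alone.

Compound 1 `CCCCC(CCO)n1cnc2c(N)ncnc21` gives > 50000 nM
Compound 2 `CCCCCCC(CCO)n1cnc2c(N(C)C)ncnc21` gives > 50000 nM

In a functional assay on HCT-116 cells (Homo sapiens) for antiproliferative activity, read by MTT assay, with a stated time of 48 h (a higher number here means a weaker inhibitor, a lower number a stronger inhibitor), compound 2 stands at > 50000 nM, which is a limit of the assay and not a number. Compound 1 also gives a limit, > 50000 nM. Among the compounds with values here, the record so far is the limit of > 50000 nM in this assay, at which 2 of the 2 values shown sit, so no measured step gives a size for any change.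

The next compound is compound 3 `CCCCCCC(CCO)n1cnc2c(N)ncnc21`, with amino in place of dimethylamino on an aromatic carbon. Compound 1 already carries amino and is expected to be the closest guide, with its result of > 50000 nM. In this assay the expected size of the change is none beyond the usual scatter, with the estimated step being a number no higher from compound 2 to compound 3 (the limit leaves the size open). Compound 3 is estimated at 50000 nM, with an expected range of 20000 nM to 100000 nM.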

Compound 3, half-maximal inhibitory concentration: > 50000 nM
Compound 3 gave a limit, no number; the forecaster's own chance of this, stated with the estimate: 70%; the middle value lies on the limit itself.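

No step can be read from compound 2 to compound 3 or from compound 1 to compound 3, since all three results in this assay are limits: the limit of > 50000 nM in this assay, at which 3 of the 3 values shown sit.
The compounds shown leave open whether amino in place of dimethylamino, or ethyl in place of hydrogen on the saturated chain, changes antiproliferative activity at all.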